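A Methyl for Methoxy Swap on the Amide Nitrogen

The compounds below may be only part of what the source reports. "The series", "measured", "known", "first", "only" and "open" are said of these compounds alone.

Going by the values given here, compound 1 `COc1cccc(N2C(=O)COc3ccc(-c4cnc(Cl)c(NS(=O)(=O)c5ccc(F)cc5)c4)cc32)c1` is the only compound with a number in a functional assay on A549 cells (Homo sapiens) for antiproliferative activity, read by MTT assay, with a stated time of 72 h (a higher number here means a weaker inhibitor, a lower number a stronger inhibitor), where compound 1 gives 32700 nM. Compound 2 `O=C1COc2ccc(-c3cnc4ccccc4c3)cc2N1` sits at the limit of > 40000 nM in this assay, at which 1 of the 2 values shown sits, and its result of > 40000 nM is a limit of the assay rather than a number. Compound 3 `Cc1ccc(N2C(=O)COc3ccc(-c4cnc(Cl)c(NS(=O)(=O)c5ccc(F)cc5)c4)cc32)cc1` carries 4-methylphenyl in place of 3-methoxyphenyl on an amide-type nitrogen in a ring. Among the compounds with values here, no measured pair differs in just one place, so nothing here sizes such a change. The step of a 1.1-fold lower number from compound 1 to compound 3 (0.04 log units; within the scatter) is expected to stay within the scatter, in no clear direction. Compound 3 is estimated at 30000 nM, between 12000 nM and 75000 nM.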

Compound 3, half-maximal inhibitory concentration: 30900 nM
For compound 3 the middle estimate is 1.0-fold (0.01 log units) below the measured one, and the stated range covers the measured number.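

In this assay the exchange of 3-methoxyphenyl for 4-methylphenyl on the amide-type nitrogen in a ring gives a 1.1-fold lower number from compound 1 to compound 3 (0.02 log units; within the scatter) and so leaves the read-out where it was. Going by these compounds alone, this is the first sized step at this position, and for this one pair, neither the different substituent nor the missing hydrogen-bond acceptor moves the number beyond the scatter. Nothing shown gives a cause for this step.

The compounds shown leave open whether an amine or a carboxylic acid on this phenyl ring would move the number. They also leave open what a longer chain on this nitrogen would do.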